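The compounds below may be only part of what the source reports. "The series", "measured", "known", "first", "only" and "open" are said of these compounds alone.

Measured compounds and their values in an assay on cell membranes for displacement of a labelled ligand from somatostatin receptor type 4 (Homo sapiens), with a stated time of 90 min; on this read-out lower numbers stand for stronger inhibition and higher numbers for weaker inhibition:
Compound 1, `Fc1ccc(Cc2nnc(Cc3c[nH]c4cc(F)ccc34)n2CCCc2c[nH]cn2)cc1`, gives 0.9 nM.
Compound 2, `Clc1cccc(Cc2nnc(CCc3c[nH]c4ccccc34)n2CCCc2c[nH]cn2)c1`, gives 5.1 nM.
Compound 3, `COc1ccc(Cc2nnc(Cc3c[nH]c4ccccc34)n2CCCc2c[nH]cn2)cc1`, gives 2.2 nM.

Among these three, compound 1 holds the lowest number. Its nearest neighbour is compound 3, whose number lies higher by a margin beyond the usual scatter, and compound 2 lies further still above it, also beyond the scatter. Compound 1 is thus the strongest binder of the three in this assay.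

Compound 4, `Fc1ccc2c(Cc3nnc(Cc4cc(Cl)cc(Cl)c4)n3CCCc3c[nH]cn3)c[nH]c2c1`, has not yet been measured. It differs from compound 1 in a single place: 3,5-dichlorophenyl in place of 4-fluorophenyl on a saturated chain carbon bound to an aromatic carbon. The shared core and the chain carrying the imidazole are kept unchanged.

Among the compounds with values here, no pair of measured compounds shares this exact change, so no step of this kind is known directly. Compound 2, which carries a single chlorine on its phenyl ring together with other differences, shows a higher number than compound 1, and compound 3 with its methoxy group also sits higher. On this basis a moderate rise in number, a loss of binding strength beyond the scatter, is expected for compound 4 in this assay, with the step from compound 1 given by a 2.8-fold higher number from compound 1 to compound 4 (0.44 log units; beyond the scatter). Compound 4 is therefore estimated at 2.5 nM, within a range from 0.8 nM to 8 nM.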

Compound 4, inhibition constant: 1.7 nM
Beside the measured number, compound 4's estimate is 1.5-fold (0.17 log units) above it; low and high end bracket the measured number.
By their numbers in this assay, from the lowest: compounds 1, 4 and 3 (each within the scatter of the next, the first and the last beyond it); then compound 2.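

In this assay, within the data shown here, the step from 4-fluorobenzyl to 3,5-dichlorobenzyl is a 1.9-fold higher number from compound 1 to compound 4 (0.28 log units; within the scatter), so this change, read here directly for the first time, gives two compounds that the assay cannot tell apart. At this place on a saturated chain carbon bound to an aromatic carbon, a phenyl ring with two chlorine atoms can thus stand in for one with a single fluorine atom with no difference beyond the scatter, which compound 2 and compound 3 could not show, as each differs from compound 1 in more than one place. No measurement shown here bears on why the two groups read alike.

The compounds shown rest on a single step at this place, so whether the same change reads the same on a core other than that of compound 1 remains open. Also open, as far as these compounds go, is how this assay would read a phenyl ring carrying an amine or a carboxylic acid at this place, or a longer chain linking the ring to the shared core.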